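Bromo to Methoxy: One Step Measured, One Step Expected

A few compounds are considered here, and "the series" means these few. Any claim that something is new, unique, unknown or untested is made for them only; others in the source may bear on it.

Compound 1 `COc1ccc(/C(Cl)=C/C=C(\C#N)C(=O)c2c[nH]c3ccc(Br)cc23)cc1` and compound 2 `COc1cc(/C(Cl)=C/C=C(\C#N)C(=O)c2c[nH]c3ccc(Br)cc23)cc(OC)c1OC` share much of their structure, but the difference between their two cores is not broken down here. In a functional assay for inhibition, with a stated time of 30 min, tested at 1 mM (a lower number here means less inhibition, a higher number more inhibition at the concentration tested (going by the name of the read-out)), compound 1 gives 15.6%, and compound 2 gives 26.3%. Compound 3 `COc1ccc(/C(Cl)=C/C=C(\C#N)C(=O)c2c[nH]c3ccc(OC)cc23)cc1` arises from compound 1 by one change, (methoxy in place of bromo on an aromatic carbon), and in this assay compound 3 gives 16.7%, so the step is a number 1.1 percentage points higher from compound 1 to compound 3 (within the scatter). Compound 4 `COc1ccc2[nH]cc(C(=O)/C(C#N)=C/C=C(\Cl)c3cc(OC)c(OC)c(OC)c3)c2c1`, not yet measured, arises from compound 2 by the same change, (methoxy in place of bromo on an aromatic carbon). A step of similar size is expected from this change, a number 1.1 percentage points higher from compound 2 to compound 4 (within the scatter), because a number 1.1 percentage points higher from compound 1 to compound 3 (within the scatter). Compound 4 is therefore estimated to give 27.4% in this assay, expected to fall between 15% and 40%.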

Compound 4, a percentage reported as inhibition, at one concentration (the size of the read-out at that concentration, not a potency): 46.1%
Compound 4: middle estimate off by 18.7 percentage points, on the low side; the whole stated range lies below it.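

In this assay, the change from bromo to methoxy on the core of compound 2 gives a number 19.8 percentage points higher from compound 2 to compound 4 (beyond the scatter). The same change did not carry over with the same size between the two cores: the same change on two cores in this assay, a number 1.1 percentage points higher (within the scatter) from compound 1 to compound 3 and a number 19.8 percentage points higher (beyond the scatter) from compound 2 to compound 4, 18.7 percentage points apart, beyond the scatter of two such steps So the effect of this swap cannot simply be copied from one of these cores to the other, but two pairs give no general rule, and they do not show which structural difference between the cores matters or why.

The compounds shown hold only bromo or methoxy at this place, so it remains open how an amine or a carboxylic acid there would behave on either core. Readings at one concentration also leave the potency of these compounds open.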